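Adding a 4-methylphenyl group to compound 1

This account rests on a few compounds, and the source may have more. Where it says the series, first, only, none or still open, it means among the compounds named here.

In an ADME assay on HEK-293T cells (Homo sapiens) for inhibition, read by CCK-8 assay, with a stated time of 48 h, tested at 20 uM (on this read-out lower numbers stand for less inhibition of growth and higher numbers for more inhibition of growth at the one concentration tested), compound 1 `Cc1ccc(S(=O)(=O)Oc2ccccc2/C=C(\C#N)C(=O)Nc2nnc(C)s2)cc1` gives 35%. Going by the values given here, that is the higher of the two numbers so far, since compound 2 `CC(=O)Nc1ccc(S(=O)(=O)Oc2cccc(/C=C(\C#N)C(=O)Nc3nnc(-c4cccs4)s3)c2)cc1` gives 20%, a gap beyond the usual scatter of repeated measurements. Compound 3 `Cc1ccc(Cc2nnc(NC(=O)/C(C#N)=C/c3ccccc3OS(=O)(=O)c3ccc(C)cc3)s2)cc1` has not yet been measured. It keeps the core of compound 1 and changes in one place: 4-methylphenyl in place of hydrogen on a saturated chain carbon bound to an aromatic carbon. In words, 4-methylphenyl stands in place of hydrogen on a saturated chain carbon bound to an aromatic carbon, which turns methyl into 4-methylbenzyl. Among the compounds with values here, no measured pair shows this change alone, so the expectation starts from compound 1 at 35%, and no step beyond the scatter is expected in this assay. The estimated step is a number 5 percentage points lower from compound 1 to compound 3 (within the scatter), a slight drop at most. For compound 3 the estimated value is 30%, with an expected range from 12% to 50%.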

Compound 3, percent growth inhibition at one concentration: 22%
Compound 3: middle estimate off by 8 percentage points, on the high side; the range from low to high includes it.
By their numbers in this assay, from the lowest: compounds 2 and 3 (each within the scatter of the next); then compound 1.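

In this assay, going by these compounds alone, turning methyl into 4-methylbenzyl on the shared core gives a number 13 percentage points lower from compound 1 to compound 3 (beyond the scatter), the first change at a single place that can be read. At this saturated chain carbon, adding one six-membered aromatic ring therefore goes with less inhibition of growth, not more, although compound 3 still gives 22% and the larger group does not bring the number to zero. Nothing measured here explains why the number falls.

A single pair cannot tell whether the ring or its methyl goes with the lower number, or whether the same step would appear on another core. Plain benzyl, ethyl or a longer chain at this place, or an amine or a carboxylic acid on the added ring, remain open.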